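Swapping the Ether Chain for Phenylsulfonyl

This account rests on a few compounds, and the source may have more. Where it says the series, first, only, none or still open, it means among the compounds named here.

Measured in a functional assay on PC-3 cells (Homo sapiens) for inhibition, read by colorimetric assay and MTT assay, with a stated time of 72 h; a lower number here means a stronger inhibitor, a higher number a weaker inhibitor:
- Compound 1 `C=CCCCCOc1cc2ccccc2cc1-c1cnc(OCCCCC=C)n1C`: 38000 nM
- Compound 2 `C=CCCCCOc1ccccc1-c1cnc(OCCCCC=C)n1C`: 9000 nM
- Compound 3 `C=CCCCCOc1ncc(-c2ccccc2OC)n1C`: 24000 nM

Compound 2 has the lowest number of the three. Compound 4 `C=CCCCCOc1ccccc1-c1cnc(S(=O)(=O)c2ccccc2)n1C` keeps most of compound 2 but carries phenylsulfonyl in place of (hex-5-en-1-yl)oxy on an aromatic carbon. Among the measured compounds shown here, no measured step touches that place. For the measured compounds named here, the only step available, a 2.7-fold higher number from compound 2 to compound 3 (0.43 log units; beyond the scatter), is modest and lies elsewhere in the molecule, so it offers only a loose guide. Going by the values given here, a rise in this assay no larger than that step is therefore expected, though the direction is uncertain. The estimated change is a 1.6-fold higher number from compound 2 to compound 4 (0.19 log units; within the scatter). For compound 4 the estimated value is 14000 nM, with an expected range of 4000 nM to 50000 nM.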

Compound 4, half-maximal inhibitory concentration: 33000 nM
Beside the measured number, compound 4's estimate is 2.4-fold (0.37 log units) below it; measured number inside the range.
By their numbers in this assay, from the lowest: compound 2; then compounds 3, 4 and 1 (each within the scatter of the next).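

At the aromatic carbon between two ring nitrogen atoms, phenylsulfonyl in place of (hex-5-en-1-yl)oxy gives a 3.7-fold higher number from compound 2 to compound 4 (0.56 log units; beyond the scatter) in this assay, so what sits at this position does matter in this assay. Compound 2, with the (hex-5-en-1-yl)oxy chain in place, keeps the lowest number of the compounds shown. Nothing measured here explains the rise.

This swap removes a chain and brings in both a sulfonyl and a benzene ring, and the compounds shown do not separate those parts. From the compounds shown here alone, whether a phenoxy group, an amine or a shorter chain such as methoxy would do better at this position remains open.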